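The source may report more compounds than this note shows. Statements on the series, on what has been measured and on what is new or still open speak of the compounds shown alone.

Measured compounds:
compound 1 `Clc1ccc(Cn2cc(C3CC(c4ccncc4)=NO3)c3ccccc32)cc1` — 9600 nM
compound 2 `COc1ccc2c(c1)c(C1CC(c3ccncc3)=NO1)cn2Cc1ccc(Cl)cc1` — 10600 nM
compound 3 `Cc1c(C2CC(c3ccncc3)=NO2)c2ccccc2n1Cc1ccc(Cl)cc1` — 8330 nM

All three were measured in a functional assay on CWR22R cells (Homo sapiens) for inhibition, read by MTT assay, with a stated time of 48 h; on this read-out lower numbers stand for stronger inhibition and higher numbers for weaker inhibition. Compound 1 stands in the middle of the three numbers, with compound 2 nearest to it, a 1.1-fold higher number from compound 1 to compound 2 (0.04 log units; within the scatter), and compound 3 furthest, a 1.2-fold lower number from compound 1 to compound 3 (0.06 log units; within the scatter); both steps lie within the scatter, so the three compounds are not separated on this read-out.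

Compound 4 `COc1ccc2c(C3CC(c4ccncc4)=NO3)cn(Cc3ccc(Cl)cc3)c2c1` is not yet measured. It differs from compound 1 by methoxy in place of hydrogen on an aromatic carbon. Among the measured compounds shown here, two measured steps bear on this change: from compound 1 to compound 2 a methoxy enters on an aromatic carbon of the same shared core, a 1.1-fold higher number from compound 1 to compound 2 (0.04 log units; within the scatter), and from compound 1 to compound 3 a methyl enters on an aromatic carbon, a 1.2-fold lower number from compound 1 to compound 3 (0.06 log units; within the scatter). Neither substitution moved the number beyond the scatter, so for the methoxy of compound 4 no step beyond the scatter in this assay is expected in either direction, a 1.0-fold lower number from compound 1 to compound 4 (0.00 log units; within the scatter). Compound 4 is therefore estimated at 9500 nM, with a range of 4500 nM to 20000 nM.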

Compound 4, half-maximal inhibitory concentration: 17300 nM
Compound 4: the middle estimate sits 1.8-fold (0.26 log units) below what was measured; measured number inside the range.
By their numbers in this assay, from the lowest: compounds 3, 1, 2 and 4 (each within the scatter of the next, the first and the last beyond it).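

At this place on the six-membered aromatic ring of the shared core, methoxy in place of hydrogen gives a 1.8-fold higher number from compound 1 to compound 4 (0.26 log units; within the scatter) in this assay and so stays within the scatter. The step of a 1.1-fold higher number from compound 1 to compound 2 (0.04 log units; within the scatter) is also within the scatter, so methoxy now stands at two different aromatic carbons of the core without either compound separating from compound 1, which a single placement could not show. Nothing on hand gives an explanation for the size of either step.

On these data alone, whether this place accepts other groups remains open: an amine, a carboxylic acid or a longer chain such as ethoxy could give a step beyond the scatter. As far as these compounds go, the remaining aromatic carbons of this ring also remain open for methoxy.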